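Phenyl for ethoxycarbonyl on a triazole-linked aryl substituent

The source may hold more compounds than are shown below. What is called first, only, known or untested is meant among the compounds shown, and "the series" means these compounds.

Measured compounds in a functional assay on PC-3 cells (Homo sapiens) for antiproliferative activity, read by MTT assay, with a stated time of 48 h; a higher number here means a weaker inhibitor, a lower number a stronger inhibitor:
- compound 1 `COc1cc(/C=C/C(C)=O)ccc1OCc1cn(-c2ccc(/N=N/c3ccccc3)cc2)nn1`: 42100 nM
- compound 2 `COc1cc(/C=C/C(C)=O)ccc1OCc1cn(-c2ccc(NC(=O)c3ccccc3)cc2)nn1`: 76800 nM
- compound 3 `CCOC(=O)c1ccc(-n2cc(COc3ccc(/C=C/C(C)=O)cc3OC)nn2)cc1`: 59200 nM

Compound 3 gives the second highest of the three numbers in this assay; its nearest neighbour is compound 2, from which it is separated by a 1.3-fold lower number from compound 2 to compound 3 (0.11 log units; within the scatter), and the furthest is compound 1, with a 1.4-fold higher number from compound 1 to compound 3 (0.15 log units; within the scatter). Both of these gaps sit within the scatter, as does a 1.8-fold higher number from compound 1 to compound 2 (0.26 log units; within the scatter), so the three measured compounds are not distinguished from one another by this assay.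

Compound 4 `COc1cc(/C=C/C(C)=O)ccc1OCc1cn(-c2ccc(-c3ccccc3)cc2)nn1` differs from compound 3 by phenyl in place of ethoxycarbonyl on an aromatic carbon. Among the measured compounds shown here, the steps that bear on this change are those in which the same position carries a group with or without a carbon ring: a 1.4-fold higher number from compound 1 to compound 3 (0.15 log units; within the scatter) and a 1.3-fold lower number from compound 2 to compound 3 (0.11 log units; within the scatter), both within the scatter. For the measured compounds named here, no measured step in this set moves the number beyond the scatter, so compound 4 is expected to show no step beyond the scatter either, a 1.2-fold lower number from compound 3 to compound 4 (0.07 log units; within the scatter). Compound 4 is therefore estimated at 50000 nM, with a range from 20000 nM to 125000 nM.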

Compound 4, half-maximal inhibitory concentration: 56800 nM
Compound 4: the middle estimate sits 1.1-fold (0.06 log units) below what was measured, and the stated range covers the measured number.
By their numbers in this assay, from the lowest: compounds 1, 4, 3 and 2 (each within the scatter of the next).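

In this assay, phenyl at this place on the aromatic ring stays within the scatter of ethoxycarbonyl (a 1.0-fold lower number from compound 3 to compound 4 (0.02 log units; within the scatter)), of benzamido (a 1.4-fold lower number from compound 2 to compound 4 (0.13 log units; within the scatter)) and of the group of 8 heavy atoms in compound 1 (a 1.3-fold higher number from compound 1 to compound 4 (0.13 log units; within the scatter)). A group of carbon only, with no hydrogen-bond acceptors, is thus not told apart from the groups carrying oxygen or nitrogen, so this assay does not separate any of the four groups shown. No measurement here accounts for this lack of separation.

Going by these compounds, whether an amine or a carboxylic acid at this place would move the number beyond the scatter remains open. So does the effect of a longer chain there, since all four groups shown end in a ring or in ethoxycarbonyl.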